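Three Full Agonists and a Difluoro Variant to Come

The compounds below may be only part of what the source reports. "The series", "measured", "known", "first", "only" and "open" are said of these compounds alone.

Compound 1, `N=C(NCCCc1c[nH]cn1)NCCSC(c1ccccc1)c1ccccn1`, gives 1 in a functional assay on cardiac atrium for agonist activity at histamine H2 receptor (Cavia porcellus); on this read-out higher numbers stand for larger maximal responses and lower numbers for smaller maximal responses.
Compound 2, `N=C(NCCCc1c[nH]cn1)NCCCC(c1ccccc1)c1ccccn1`, gives 1 in this assay.
Compound 3, `N=C(NCCCc1c[nH]cn1)NCCC(c1ccc(Br)cc1)c1ccccn1`, gives 1 in this assay.

All three measured compounds reach the same maximal response in this assay. Compound 3 therefore stands level with compounds 1 and 2 at the digits shown; its nearest neighbour on the numbers is compound 1 and its furthest is compound 2, yet neither gap is anything beyond the usual scatter. Each compound gives the full response of the reference agonist.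

Compound 4, `N=C(NCCCc1c[nH]cn1)NCCC(c1cc(F)cc(F)c1)c1ccccn1`, has not yet been tested. It differs from compound 3 in one place: 3,5-difluorophenyl in place of 4-bromophenyl on a saturated chain carbon bound to an aromatic carbon and a saturated chain carbon. Since compounds 1, 2 and 3 differ from one another in the linker and in the aryl group and still give the same maximal response, the swap of one substituted phenyl for another is expected to leave the maximal response unchanged, giving an expected step from compound 3 to compound 4 of no change at the digits printed from compound 3 to compound 4 (within the scatter), which is none beyond the scatter. Compound 4 is therefore estimated to give 1 in this assay, with an expected range from 0.85 to 1.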

Compound 4, intrinsic activity: the largest response reached, as a fraction of the reference agonist's: 1
The estimate for compound 4 equals the measured number at the digits printed; low and high end bracket the measured number.
By their numbers in this assay, from the lowest: compounds 1, 2, 3 and 4 (each within the scatter of the next).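

Among these compounds, this is the first pair that differs in one place only, and in this assay the change gives no change at the digits printed from compound 3 to compound 4 (within the scatter). On a saturated chain carbon bound to an aromatic carbon and a saturated chain carbon, 3,5-difluorophenyl can therefore take the place of 4-bromophenyl, swapping one bromine for two fluorines on the ring, and the maximal response still holds. Nothing measured here accounts for this result, so the reason stays unknown.

Going by these compounds, it remains open whether the response would also hold with a phenyl ring carrying an amine or a carboxylic acid at this place. A maximal response also leaves open how much of each compound is needed to reach it.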